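The source may report more compounds than this note shows. Statements on the series, on what has been measured and on what is new or still open speak of the compounds shown alone.

Measured so far in a functional assay on HepG2 cells (Homo sapiens) for antiproliferative activity, read by CCK-8 assay, with a stated time of 48 h; a higher number here means a weaker inhibitor, a lower number a stronger inhibitor:
Compound 1 `COc1ccc(/C=C\c2cc(OC)c(OC)c(OC)c2)cc1OCc1ccc(CN2CC(C(=O)O)C2)cc1` — compound 1 gives > 10000 nM, which is a limit of the assay, not a number.
Compound 2 `COc1ccc(/C=C\c2cc(OC)c(OC)c(OC)c2)cc1OCc1ccc(CN2C[C@H](O)C[C@@H]2C(=O)O)cc1` — compound 2 gives > 10000 nM, again a limit and not a number.

Compound 2 therefore stands only at a limit in this assay; no number is known for it. Going by the values given here, the single measured step, a step that the two limits leave unreadable from compound 1 to compound 2, cannot be sized because of the limit of > 10000 nM in this assay, at which 2 of the 2 values shown sit.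

Compound 3 `COc1ccc(/C=C\c2cc(OC)c(OC)c(OC)c2)cc1OCc1ccc(CN2CCCCC2C(=O)NCCN)cc1` differs from compound 2 by 2-((2-aminoethyl)carbamoyl)piperidin-1-yl in place of 2-carboxy-4-hydroxypyrrolidin-1-yl on a saturated chain carbon bound to an aromatic carbon. No readable measured step bears on this change, so there is no ground for expecting a step beyond the scatter in either direction. Compound 3 is expected near 15000 nM, with a range from 2000 nM to 50000 nM. The expected step is a step that the limit leaves unreadable from compound 2 to compound 3, and a limit rather than a number is the likelier outcome.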

Compound 3, half-maximal inhibitory concentration: 4800 nM
Compound 3: the middle estimate sits 3.1-fold (0.49 log units) above what was measured, and the stated range covers the measured number.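

On a saturated chain carbon bound to an aromatic carbon, this change gives the first measurable activity in this assay: 2-((2-aminoethyl)carbamoyl)piperidin-1-yl produces an at least 2.0-fold lower number from compound 2 to compound 3 (0.31 log units; beyond the scatter), and an at least 2.0-fold lower number from compound 1 to compound 3 (0.31 log units; beyond the scatter). The full size of both steps cannot be read because each starting compound sits at a limit: the limit of > 10000 nM in this assay, at which 2 of the 3 values shown sit.

The ring and its attached group change together, and the compounds shown do not separate their contributions. A 2-carboxypiperidin-1-yl group at this place would compare the six-membered ring with the 2-aminoethyl amide.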